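This account rests on a few compounds, and the source may have more. Where it says the series, first, only, none or still open, it means among the compounds named here.

Working notes on the series. Compound 3 `c1ccc(-c2ncnc3c2ncn3C2CCOCC2)cc1` is recorded in a functional assay on K562 cells (Homo sapiens), read by thymidine incorporation (on this read-out higher numbers stand for weaker inhibition and lower numbers for stronger inhibition), only at a limit, < 10 ug/mL. Compound 1 `Cn1cnc2c(-c3ccco3)ncnc21` likewise sits at a limit in this assay, < 10 ug/mL. Compound 2 `c1coc(-c2ncnc3c2ncn3CC2CCCCC2)c1` gives a number in this assay, 60 ug/mL. Among the compounds with values here, the single measured step, an at least 6.0-fold higher number from compound 1 to compound 2 (0.77 log units; beyond the scatter), concerns the group on the saturated chain carbon bound to the aromatic nitrogen and leaves the aryl group untouched. It should be read against (the limit of < 10 ug/mL in this assay, at which 2 of the 3 values shown sit).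

The change to compound 4 `c1coc(-c2ncnc3c2ncn3C2CCOCC2)c1` is furan-2-yl in place of phenyl on an aromatic carbon. Within the data shown here, no measured step bears on this exchange: compound 1 and compound 2 both carry furan-2-yl, and compound 3 alone carries phenyl, so no measured pair isolates the aryl swap. With compound 3 standing at the limit and nothing measured pointing either way, the step that the limit leaves unreadable from compound 3 to compound 4 is expected to stay within the scatter. Compound 4 is therefore estimated at 8 ug/mL, with a range of 3 ug/mL to 25 ug/mL, and may well be reported as a limit again.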

Compound 4, half-maximal inhibitory concentration: 15 ug/mL
For compound 4 the middle estimate is 1.9-fold (0.27 log units) below the measured one; low and high end bracket the measured number.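

In this assay, the aryl exchange on the aromatic carbon can now be read, though only as a floor: an at least 1.5-fold higher number from compound 3 to compound 4 (0.17 log units; that floor lies within the scatter). That floor does not separate furan-2-yl from phenyl. On the aromatic nitrogen, oxan-4-yl gives a clear gain over cyclohexylmethyl with furan-2-yl held constant, a 4.0-fold lower number from compound 2 to compound 4 (0.60 log units; beyond the scatter), while the comparison with methyl, an at least 1.5-fold higher number from compound 1 to compound 4 (0.17 log units; that floor lies within the scatter), again gives only a floor that does not separate the two groups, and both floors rest on a limit: the limit of < 10 ug/mL in this assay, at which 2 of the 4 values shown sit.

As far as these compounds go, how far compound 1 and compound 3 lie past their limits remains open, so the true size of these two steps is unknown. Also open, from the compounds shown here alone, is how an amine or a longer chain on the aromatic nitrogen would read in this assay.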